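Carbonyl substituent variation in a vitamin D3 receptor agonist series

This account rests on a few compounds, and the source may have more. Where it says the series, first, only, none or still open, it means among the compounds named here.

Measured compounds:
compound 1 `CC[C@@H](C)[C@H](NC(=O)c1ccc(C(CC)(CC)c2ccc(OCC(O)C(C)(C)C)c(C)c2)n1CC)C(=O)OC` gives 26 nM in an assay on HL-60 cells for agonist activity at vitamin D3 receptor (Homo sapiens), read by microscopy, with a stated time of 96 h; on this read-out lower numbers stand for an effect already at smaller amounts and higher numbers for an effect only at larger amounts of compound
compound 2 `CCn1c(C(=O)N(CCC#N)CCC#N)ccc1C(CC)(CC)c1ccc(OCC(O)C(C)(C)C)c(C)c1` gives 97 nM
compound 3 `C#CC(C)OC(=O)c1ccc(C(CC)(CC)c2ccc(OCC(O)C(C)(C)C)c(C)c2)n1CC` gives 200 nM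

Compound 3 stands at the highest number of the three in this assay; its nearest neighbour is compound 2, with a 2.1-fold higher number from compound 2 to compound 3 (0.31 log units; beyond the scatter), and the furthest is compound 1, with a 7.7-fold higher number from compound 1 to compound 3 (0.89 log units; beyond the scatter). Both of these steps run beyond the scatter, so compound 3 is the weakest of the measured set.

Compound 4 `CCn1c(C(=O)Nc2ccc(OC(F)(F)F)cc2)ccc1C(CC)(CC)c1ccc(OCC(O)C(C)(C)C)c(C)c1` differs from compound 3 by (4-(trifluoromethoxy)phenyl)amino in place of (1-methylprop-2-yn-1-yl)oxy on a carbonyl carbon. As in compound 1 and compound 2, the carbonyl carbon now carries an amino substituent rather than an oxygen-linked one. For the measured compounds named here, the steps that bear on this are the two that lead from such substituents to compound 3: a 7.7-fold higher number from compound 1 to compound 3 (0.89 log units; beyond the scatter) and a 2.1-fold higher number from compound 2 to compound 3 (0.31 log units; beyond the scatter), both modest and both in the same direction. Going by the values given here, the aryl amine of compound 4 is a new type within the set, and no step shows how it compares with the substituents of compound 1 or compound 2. A step in this assay in the direction of the lower numbers is therefore expected, of the size a 2.9-fold lower number from compound 3 to compound 4 (0.46 log units; beyond the scatter). For compound 4 the estimate in this assay is 70 nM, within 18 nM to 280 nM.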

Compound 4, half-maximal effective concentration: > 50000 nM
Compound 4: no number, only a limit; the forecaster's own chance of this, stated with the estimate: 5%; middle value at least 710-fold (2.85 log units) from the limit.
By their numbers in this assay, from the lowest: compound 1; then compound 2; then compound 3. At a limit, above all of these: compound 4.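

Compound 4 gives no number in this assay, only a limit: the limit of > 50000 nM in this assay, at which 1 of the 4 values shown sits.

The earlier compounds shown here showed only modest steps at this carbonyl carbon, whereas the steps to compound 4 are all large: an at least 250-fold higher number from compound 3 to compound 4 (2.39 log units; beyond the scatter), an at least 510-fold higher number from compound 2 to compound 4 (2.71 log units; beyond the scatter) and an at least 1900-fold higher number from compound 1 to compound 4 (3.28 log units; beyond the scatter). An amino substituent on the carbonyl carbon therefore does not by itself keep the number low, since compound 1 and compound 2 stand lowest of the set while compound 4, also an amide, stands at the limit; the step from compound 1 is the sharpest case, with only the group on the amide-type nitrogen changing, and (4-(trifluoromethoxy)phenyl)amino is also the only substituent here with a ring.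

The compounds shown do not separate the part played by the aromatic ring from that of the trifluoromethoxy group, a question that plain phenylamino or 4-methoxyphenylamino would address. They also leave open whether a benzylamino group, which sets a methylene between the nitrogen and the ring, would return to the range of compound 1 and compound 2.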